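The source may hold more compounds than are shown below. What is called first, only, known or untested is meant among the compounds shown, and "the series" means these compounds.

Measured so far in an ADME assay on WI-38 cells (Homo sapiens) for cytotoxicity, read by MTT assay, with a stated time of 72 h; a lower number here means a stronger inhibitor, a higher number a weaker inhibitor:
Compound 1 `O=C(CCc1cccc2c1B(O)OC2)Nc1cccc(Br)c1`: 20000 nM
Compound 2 `O=C(CCc1cccc2c1B(O)OC2)Nc1cccc(-c2ccc(Cl)cc2)c1`: 9800 nM

Among the compounds with values here, of these two compounds, compound 2 has the lower number, at 9800 nM, and compound 1 is its only neighbour on the scale. The next compound, compound 3 `O=C(CCc1cccc2c1B(O)OC2)Nc1cccc(-c2ccc(C(F)(F)F)cc2)c1`, keeps the whole of compound 2 except for one group: trifluoromethyl in place of chloro on an aromatic carbon. The same difference can be read as 4-chlorophenyl to 4-(trifluoromethyl)phenyl, with the new group para to a large group.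

Within the data shown here, only one measured step bears on this change. That step, a 2.0-fold lower number from compound 1 to compound 2 (0.31 log units; beyond the scatter), is modest and comes from 4-chlorophenyl in place of bromo. Among the measured compounds shown here, it shows a small shift in this assay at this end of the molecule, but no measured pair varies the group on the 4-chlorophenyl itself. No step beyond the scatter is therefore expected, and a shift in either direction remains possible. The estimated change is a 1.1-fold lower number from compound 2 to compound 3 (0.04 log units; within the scatter). For compound 3 the expected value is 9000 nM, with an estimated range of 4500 nM to 18000 nM.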

Compound 3, half-maximal inhibitory concentration: 26000 nM
Compound 3: middle estimate off by 2.9-fold (0.46 log units), on the low side; the whole stated range lies below it.
By their numbers in this assay, from the lowest: compound 2; then compounds 1 and 3 (each within the scatter of the next).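

In this assay, the group on the aromatic carbon para to a large group turns out to count: a 2.7-fold higher number from compound 2 to compound 3 (0.42 log units; beyond the scatter), the first measured change made at that place, and it is beyond the scatter. It also qualifies what the earlier pair seemed to show, since a 1.3-fold higher number from compound 1 to compound 3 (0.11 log units; within the scatter), which lies within the scatter. Putting an aryl group in place of bromo therefore does not by itself give a lower number, as 4-(trifluoromethyl)phenyl does not repeat the modest step seen with 4-chlorophenyl. No measurement at hand accounts for the difference between chloro and trifluoromethyl at this place.

The compounds shown leave open whether chloro is unusual among groups at this place or whether trifluoromethyl is the exception, and a plain hydrogen, a fluorine, a methoxy group or an amine there would help to separate those two readings. They also leave open whether the gap between compound 2 and compound 3 would persist with a longer chain between the shared core and the amide carbonyl.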